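Replacing Methoxy With Hydrogen on Compound 3

A few compounds are considered here, and "the series" means these few. Any claim that something is new, unique, unknown or untested is made for them only; others in the source may bear on it.

In an ADME assay on MT4 cells (Homo sapiens) for cytotoxicity, read by spectrophotometry, with a stated time of 5 days (on this read-out higher numbers stand for lower toxicity in this test and lower numbers for higher toxicity in this test), compound 3 (`COc1ccc(N2CCN(CN3C(=O)/C(=N\NC(=S)NO)c4cc(Cl)ccc43)CC2)cc1`) gives 279000 nM, within the scatter of compound 1 (`COc1ccc(N2CCN(CN3C(=O)/C(=N\NC(=S)NO)c4cc(F)ccc43)CC2)cc1`) at 260000 nM and of compound 2 (`Cc1ccc2c(c1)/C(=N/NC(=S)NO)C(=O)N2CN1CCN(c2ccccc2)CC1`) at 420000 nM. Compound 4 (`O=C1/C(=N\NC(=S)NO)c2cc(Cl)ccc2N1CN1CCN(c2ccccc2)CC1`) has hydrogen in place of methoxy on an aromatic carbon, para to a large group: hydrogen in place of methoxy on an aromatic carbon. For the measured compounds named here, the only measured step, a 1.1-fold higher number from compound 1 to compound 3 (0.03 log units; within the scatter), exchanges fluoro for chloro, lies within the scatter and leaves the methoxy untouched, so no measured step isolates this change. Compound 2, which also carries phenyl rather than 4-methoxyphenyl, gives 420000 nM, which offers indirect support. The expected 1.1-fold higher number from compound 3 to compound 4 (0.06 log units; within the scatter) therefore stays within the scatter, with no clear direction. For compound 4 the estimated value is 320000 nM, with an expected range of 180000 nM to 570000 nM.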

Compound 4, half-maximal cytotoxic concentration: 273000 nM
For compound 4 the middle estimate is 1.2-fold (0.07 log units) above the measured one; low and high end bracket the measured number.
By their numbers in this assay, from the lowest: compounds 1, 4, 3 and 2 (each within the scatter of the next).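

In this assay, for the compounds shown here, the step of a 1.0-fold lower number from compound 3 to compound 4 (0.01 log units; within the scatter) gives the first direct reading of hydrogen in place of methoxy, and it lies within the scatter. Going by these compounds alone, the step of a 1.5-fold lower number from compound 2 to compound 4 (0.19 log units; within the scatter) also lies within the scatter and gives the first reading of chloro in place of methyl with the phenyl group held constant. No measurement shown offers an explanation for either result.

Hydrogen and methoxy are the only groups compared at this place. As far as these compounds go, whether an amine or a carboxylic acid there would give a number beyond the scatter remains open.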